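Removing a Bromine From an Oxadiazole Amine Pair

The compounds below may be only part of what the source reports. "The series", "measured", "known", "first", "only" and "open" are said of these compounds alone.

Compound 1, `C#CCN(c1nc(-c2cccc(Br)c2)no1)C1CCCCC1`, gives 53.5 ug/mL in an ADME assay on HepG2 cells (Homo sapiens) for cytotoxicity, read by MTT assay, with a stated time of 48 h; a higher number here means that more compound is tolerated, a lower number that less compound is tolerated.
Compound 2, `C#CCN(c1nc(-c2ccccc2)no1)C1CCCCC1`, gives 109 ug/mL.
Compound 3, `CC(=O)OC[C@H]1O[C@H](OC[C@@H](Cn2cc(CN(c3nc(-c4ccc(Br)cc4)no3)C3CCCCC3)nn2)OC(C)=O)C=C[C@@H]1OC(C)=O`, gives 47.6 ug/mL.

Compound 4, `CC(=O)OC[C@H]1O[C@H](OC[C@@H](Cn2cc(CN(c3nc(-c4ccccc4)no3)C3CCCCC3)nn2)OC(C)=O)C=C[C@@H]1OC(C)=O`, has not yet been measured. From compound 1 to compound 2 the change is hydrogen in place of bromo on an aromatic carbon, and the result was a 2.0-fold higher number from compound 1 to compound 2 (0.31 log units; beyond the scatter). From compound 3 to compound 4 the change is hydrogen in place of bromo on an aromatic carbon. These are the same kind of change, though the place is not identical: meta to a large group in the first, para to a large group in the second. How the core of compound 1 differs from that of compound 3 is not broken down here. Compound 3 lies within the scatter of compound 1. Because the earlier step read a 2.0-fold higher number from compound 1 to compound 2 (0.31 log units; beyond the scatter), a similar step is expected here. The expected step is a 2.0-fold higher number from compound 3 to compound 4 (0.30 log units; within the scatter). Compound 4 is therefore estimated at 95 ug/mL, most likely between 50 ug/mL and 180 ug/mL.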

Compound 4, half-maximal cytotoxic concentration: 19.9 ug/mL
Compound 4: the middle estimate sits 4.8-fold (0.68 log units) above what was measured; measured number below the stated range.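

Replacing bromo with hydrogen gave a 2.4-fold lower number from compound 3 to compound 4 (0.38 log units; beyond the scatter) in this assay. Among these compounds, the change therefore did not carry over between these two cores, and even its direction reversed: the same change on two cores in this assay, a 2.0-fold higher number (0.31 log units; beyond the scatter) from compound 1 to compound 2 and a 2.4-fold lower number (0.38 log units; beyond the scatter) from compound 3 to compound 4, 4.9-fold (0.69 log units) apart, beyond the scatter of two such steps With only two pairs, this sets no rule for the series, and it does not show whether the core or the bromine's place on the ring decides the outcome, as the pairs differ in both.

A matched pair with the 4-bromophenyl group on the core of compound 1 could separate those two differences. From the compounds shown here alone, how a chloro or methyl group in the bromine's place would read on either core also remains open.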